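Aromatic rings in place of alkyl groups on the core

The compounds below may be only part of what the source reports. "The series", "measured", "known", "first", "only" and "open" are said of these compounds alone.

Compound 1 `Cc1cc(C)c(N2CCN(c3ncccn3)CC2)nn1` gives > 100000 nM in a functional assay on BV-2 cells (Mus musculus) for inhibition, read by ELISA, with a stated time of 16 h (on this read-out lower numbers stand for stronger inhibition and higher numbers for weaker inhibition), a limit rather than a number. Compound 2 `Cc1cc(C(C)C)nnc1N1CCN(c2ncccn2)CC1` gives > 100000 nM in this assay, again a limit. Compound 3 `COc1cccc(-c2cc(C)c(N3CCN(c4ncccn4)CC3)nn2)c1` gives 2600 nM in this assay.

Compound 2 stands at the limit of > 100000 nM in this assay, at which 2 of the 3 values shown sit, so only a limit is known for it. Compound 4 `Cc1cc(-c2ccc(F)cc2)nnc1N1CCN(c2ncccn2)CC1` differs from compound 2 in one place: 4-fluorophenyl in place of isopropyl on an aromatic carbon. The step that bears most directly on this is an at least 38-fold lower number from compound 2 to compound 3 (1.58 log units; beyond the scatter), where 3-methoxyphenyl replaced the same isopropyl group; an at least 38-fold lower number from compound 1 to compound 3 (1.58 log units; beyond the scatter) points the same way. A large drop in the number is therefore expected for compound 4, as the step of an at least 33-fold lower number from compound 2 to compound 4 (1.52 log units; beyond the scatter). Compound 4 is estimated to give 3000 nM, with a range from 800 nM to 15000 nM.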

Compound 4, half-maximal inhibitory concentration: 76300 nM
The estimate for compound 4 lay 25-fold (1.41 log units) below the measured number; measured number above the stated range.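

Swapping in an aromatic ring at this position does not by itself lower the number in this assay, and the choice of ring matters greatly: the change from 3-methoxyphenyl to 4-fluorophenyl gives a 29-fold higher number from compound 3 to compound 4 (1.47 log units; beyond the scatter). Against the alkyl groups, 4-fluorophenyl shows no clear gain, with an at least 1.3-fold lower number from compound 2 to compound 4 (0.11 log units; that floor lies within the scatter) and an at least 1.3-fold lower number from compound 1 to compound 4 (0.11 log units; that floor lies within the scatter).

The compounds shown leave open whether compound 3 owes its lower number to the methoxy group or to that group's place on the phenyl ring. As far as these compounds go, how a plain phenyl or a 3-fluorophenyl group would fare here remains unknown.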